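Adding a para-fluorine back onto compound 3's phenyl

The source may report more compounds than this note shows. Statements on the series, on what has been measured and on what is new or still open speak of the compounds shown alone.

Compound 3 `O=C(Nc1ccc(Oc2ccnc3[nH]ccc23)c(F)c1)c1cc(-c2ccccc2)ncn1` is the second highest of three numbers in a functional assay on A549 cells (Homo sapiens) for cytotoxicity, read by MTT assay, with a stated time of 72 h (on this read-out higher numbers stand for weaker inhibition and lower numbers for stronger inhibition), where compound 3 gives 180 nM. Its nearest neighbour is compound 2 `O=C(Nc1ccc(Oc2ccnc3[nH]ccc23)cc1)c1cc(-c2ccccc2)ncn1`, which in this assay gives 140 nM, a difference within the scatter; the furthest is compound 1 `O=C(Nc1ccc(Oc2ccnc3[nH]ccc23)cc1)c1cc(-c2ccc(F)cc2)ncn1`, which gives 13000 nM. Compound 4 `O=C(Nc1ccc(Oc2ccnc3[nH]ccc23)c(F)c1)c1cc(-c2ccc(F)cc2)ncn1` differs from compound 3 by fluoro in place of hydrogen on an aromatic carbon. The step that bears most directly on this is the reverse of it, a 93-fold lower number from compound 1 to compound 2 (1.97 log units; beyond the scatter), a large one; the step of a 1.3-fold higher number from compound 2 to compound 3 (0.11 log units; within the scatter) concerns a fluorine elsewhere and is within the scatter. Compound 4 is therefore expected to show a large step to a higher number, a 67-fold higher number from compound 3 to compound 4 (1.82 log units; beyond the scatter). The estimate for compound 4 in this assay is 12000 nM, with a range from 1500 nM to 60000 nM.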

Compound 4, half-maximal inhibitory concentration: 14200 nM
Beside the measured number, compound 4's estimate is 1.2-fold (0.07 log units) below it; the measured number falls inside the stated range.
By their numbers in this assay, from the lowest: compounds 2 and 3 (each within the scatter of the next); then compounds 1 and 4 (each within the scatter of the next).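

In this assay, the change from phenyl to 4-fluorophenyl gives a 79-fold higher number from compound 3 to compound 4 (1.90 log units; beyond the scatter), so the large step seen earlier on one core returns at nearly the same size on a second core: the same change on two cores in this assay, a 93-fold lower number (1.97 log units; beyond the scatter) from compound 1 to compound 2 and a 79-fold lower number (1.90 log units; beyond the scatter) from compound 4 to compound 3, 1.2-fold (0.07 log units) apart, within the scatter of two such steps The other fluorine, which made no readable difference with a phenyl present, also stays within the scatter with a 4-fluorophenyl present, at a 1.1-fold higher number from compound 1 to compound 4 (0.04 log units; within the scatter): the same change on two cores in this assay, a 1.3-fold higher number (0.11 log units; within the scatter) from compound 2 to compound 3 and a 1.1-fold higher number (0.04 log units; within the scatter) from compound 1 to compound 4, 1.2-fold (0.07 log units) apart, within the scatter of two such steps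

With only hydrogen and fluoro at this place among the compounds shown, how a chloro, methoxy or amino group there would read remains open.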